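A few compounds are considered here, and "the series" means these few. Any claim that something is new, unique, unknown or untested is made for them only; others in the source may bear on it.

Going by the values given here, in a toxicity assay on GES1 cells (Homo sapiens) for inhibition, read by MTT assay, with a stated time of 72 h (on this read-out higher numbers stand for weaker inhibition and lower numbers for stronger inhibition), compound 2 `Cc1cc(N2CC[C@@H](C)[C@@H](N(C)c3ncnc4[nH]ccc34)C2)n2nc(SCC3CCCCC3)nc2n1` gives 98200 nM, the only true number so far. Compound 1 `Cc1cc(N2CC[C@@H](C)[C@@H](N(C)c3ncnc4[nH]ccc34)C2)n2nc(SCc3csc4ccc(Cl)cc34)nc2n1` reads > 100000 nM, which is a limit of the assay and not a number. Compound 3 `COc1ccc(CSc2nc3nc(C)cc(N4CC[C@@H](C)[C@@H](N(C)c5ncnc6[nH]ccc56)C4)n3n2)cc1` carries 4-methoxyphenyl in place of cyclohexyl on a saturated chain carbon bound to a sulfur. Among the compounds with values here, the one measured step at that place is an at least 1.0-fold lower number from compound 1 to compound 2 (0.00 log units; that floor lies within the scatter), so it offers no sign of a large shift. No change beyond the scatter is therefore expected in this assay. The expected step is a 1.1-fold lower number from compound 2 to compound 3 (0.04 log units; within the scatter). The estimate for compound 3 is 90000 nM, with a range of 40000 nM to 150000 nM.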

Compound 3, half-maximal inhibitory concentration: > 100000 nM
Compound 3 gave a limit, no number (the forecaster's own chance of this, stated with the estimate: 45%); at least 1.1-fold (0.04 log units) between middle value and limit.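

In this assay, putting 4-methoxyphenyl in place of cyclohexyl on a saturated chain carbon bound to a sulfur gives an at least 1.0-fold higher number from compound 2 to compound 3 (0.00 log units; that floor lies within the scatter). The reading for compound 3 is a limit of the assay and not a number, so this step gives only a floor, and the step that links compound 1 and compound 3 cannot be read. A second aromatic group at this place now ends at the same ceiling: the limit of > 100000 nM in this assay, at which 2 of the 3 values shown sit.

As far as these compounds go, whether a primary amine or a carboxylic acid at this place would bring a number far below that ceiling stays open.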